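From (pyridin-4-yl)methyl to isopropyl on the aromatic nitrogen

A few compounds are considered here, and "the series" means these few. Any claim that something is new, unique, unknown or untested is made for them only; others in the source may bear on it.

In a functional assay on cells (Platelet, Homo sapiens) for inhibition (on this read-out lower numbers stand for stronger inhibition and higher numbers for weaker inhibition), compound 3 `CCOC(=O)c1ccc(-c2nn(Cc3ccncc3)c3ccccc23)cc1` gives 5630 nM, the highest number of the three measured, against compound 1 `CCOC(=O)c1ccc(-c2nn(C)c3ccccc23)cc1` at 270 nM and compound 2 `CCOC(=O)c1ccc(-c2nn(Cc3cccc(Cl)c3)c3ccccc23)cc1` at 80 nM. Compound 4 `CCOC(=O)c1ccc(-c2nn(C(C)C)c3ccccc23)cc1` carries isopropyl in place of (pyridin-4-yl)methyl on an aromatic nitrogen. Within the data shown here, three measured steps bear on this: the large 21-fold higher number from compound 1 to compound 3 (1.32 log units; beyond the scatter) and a 70-fold higher number from compound 2 to compound 3 (1.85 log units; beyond the scatter), and the modest 3.4-fold lower number from compound 1 to compound 2 (0.53 log units; beyond the scatter). The pyridin-4-yl group leaves, and compound 1 at 270 nM, which also lacks it, serves as the nearest reference. A large step to a lower number is expected, namely a 28-fold lower number from compound 3 to compound 4 (1.45 log units; beyond the scatter). For compound 4 the estimate is 200 nM, with an expected range from 60 nM to 700 nM.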

Compound 4, half-maximal inhibitory concentration: 650 nM
Compound 4: middle estimate off by 3.3-fold (0.51 log units), on the low side; measured number inside the range.
By their numbers in this assay, from the lowest: compound 2; then compound 1; then compound 4; then compound 3.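

In this assay, replacing (pyridin-4-yl)methyl with isopropyl gives an 8.7-fold lower number from compound 3 to compound 4 (0.94 log units; beyond the scatter), but isopropyl does not match methyl, with a 2.4-fold higher number from compound 1 to compound 4 (0.38 log units; beyond the scatter), or 3-chlorobenzyl, with an 8.1-fold higher number from compound 2 to compound 4 (0.91 log units; beyond the scatter). Among the groups on this aromatic nitrogen, the number does not follow group size: compound 4 lies above compound 1, while the two ring-bearing groups fall at opposite ends, with compound 2 lowest and compound 3 highest. No measurement offered here accounts for these differences.

Still open, as far as these compounds go, is where an unsubstituted benzyl, a longer chain such as n-butyl, or a chain ending in an amine would fall.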